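A methyl scan on the core of compound 1

A few compounds are considered here, and "the series" means these few. Any claim that something is new, unique, unknown or untested is made for them only; others in the source may bear on it.

Measured in a functional assay on SK-MEL-5 cells (Homo sapiens); a lower number here means a stronger inhibitor of growth, a higher number a weaker inhibitor of growth:
- compound 1 `COc1ccccc1-c1cc(O)c2cccnc2n1`: 31600 nM
- compound 2 `COc1ccccc1-c1cc(O)c2c(C)ccnc2n1`: 22400 nM

For the measured compounds named here, compound 1 has only one measured neighbour, and the two values lie within the scatter of each other. Compound 1 therefore stands level with compound 2 in this assay, and both sit at the weak end of what a growth inhibitor would need to show.

Compound 3 `COc1ccccc1-c1cc(O)c2cc(C)cnc2n1` is still to be measured. It differs from compound 1 as follows: methyl in place of hydrogen on an aromatic carbon.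

Going by the values given here, one measured step bears on this change, the same kind of exchange of hydrogen for methyl made at a different place on the core: a 1.4-fold lower number from compound 1 to compound 2 (0.15 log units; within the scatter). That step stays within the scatter. Among the compounds with values here, no measurement yet covers a methyl at the place it occupies in compound 3, so the evidence is thin, and no step beyond the scatter is expected.

The expected change is a 1.3-fold lower number from compound 1 to compound 3 (0.10 log units; within the scatter), an estimate that stays within the scatter.

For compound 3 the estimated value is 25000 nM, with an expected range of 12000 nM to 52000 nM.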

Compound 3, concentration for 50% growth inhibition: 20400 nM
The estimate for compound 3 lay 1.2-fold (0.09 log units) above the measured number; the range from low to high includes it.
By their numbers in this assay, from the lowest: compounds 3, 2 and 1 (each within the scatter of the next).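

In this assay, methyl in place of hydrogen on the aromatic carbon two atoms from the ring nitrogen gives a step that stays within the scatter (a 1.5-fold lower number from compound 1 to compound 3 (0.19 log units; within the scatter)). This adds a second place on the core where the same exchange leaves the number within the scatter, alongside the earlier step (a 1.4-fold lower number from compound 1 to compound 2 (0.15 log units; within the scatter)), so neither methyl separates from compound 1 in this growth read-out. Compound 3 (20400 nM) therefore stays level with compound 1 and at the weak end for a growth inhibitor, and no measured evidence on hand accounts for this flat response.

Still open, from the compounds shown here alone, is whether this place responds only to something larger or different from methyl, such as a longer chain, an amine or a carboxylic acid, any of which could show whether the position can move the number beyond the scatter at all. Also open, going by these compounds, is whether changes away from these two ring carbons, for instance replacing the methoxy group or the hydroxyl on the shared core, would shift growth inhibition where methyl has not.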